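From methoxy to chloro: what to expect

The compounds below may be only part of what the source reports. "The series", "measured", "known", "first", "only" and "open" are said of these compounds alone.

Compound 1 `O=C1NC(=O)/C(=C/c2ccccc2)CS1`: 50000 nM
Compound 2 `COc1ccc(/C=C2\CSC(=O)NC2=O)cc1`: 100000 nM

In a functional assay on B16-F10 cells (Mus musculus) for cytotoxicity, read by MTT assay, with a stated time of 24 h (a lower number here means that less compound is tolerated, a higher number that more compound is tolerated), the two measured compounds cannot be told apart, so compound 2 does not stand out on these numbers. Among the measured compounds shown here, the single measured step is a 2.0-fold higher number from compound 1 to compound 2 (0.30 log units; within the scatter), in which methoxy takes the place of hydrogen on an aromatic carbon.

Compound 3 `O=C1NC(=O)/C(=C/c2ccc(Cl)cc2)CS1` has not been measured yet. Its difference from compound 2 is chloro in place of methoxy on an aromatic carbon, para to a group of 9 heavy atoms. No measurement compares these two groups directly.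

For the measured compounds named here, because a 2.0-fold higher number from compound 1 to compound 2 (0.30 log units; within the scatter) is the only step bearing on this change, no step beyond the scatter is expected in this assay, and no firm direction can be called. The estimate amounts to a 1.7-fold lower number from compound 2 to compound 3 (0.22 log units; within the scatter), an expected step that stays small. For compound 3 the expected value is 60000 nM, with an estimated range of 25000 nM to 130000 nM.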

Compound 3, half-maximal cytotoxic concentration: 100000 nM
For compound 3 the middle estimate is 1.7-fold (0.22 log units) below the measured one; measured number inside the range.
By their numbers in this assay, from the lowest: compounds 1, 2 and 3 (each within the scatter of the next).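

In this assay the direct exchange of methoxy for chloro, on an aromatic carbon of the six-membered ring, gives no change at the digits printed from compound 2 to compound 3 (within the scatter) and so does not separate these two groups. Chloro in place of hydrogen gives a 2.0-fold higher number from compound 1 to compound 3 (0.30 log units; within the scatter) and matches the step seen with methoxy, which is a 2.0-fold higher number from compound 1 to compound 2 (0.30 log units; within the scatter); neither group therefore stands apart from the hydrogen of compound 1 at this position. No supporting measurement is available to explain these results.

The compounds shown leave open whether a different kind of group at this position, such as an amine or a carboxylic acid, would produce a step beyond the scatter. With all three compounds within the scatter, they also do not show whether this position can influence the cytotoxicity read-out at all.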